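A few compounds are considered here, and "the series" means these few. Any claim that something is new, unique, unknown or untested is made for them only; others in the source may bear on it.

Measured so far:
compound 1, `Cc1ccccc1Oc1ccc(C#N)cc1S(=O)(=O)NC(=O)NC(C)C`, with 6130 nM in a functional assay on HEK293 cells for antagonist activity at thromboxane A2 receptor (Homo sapiens), read by fluorescence and calcium flux; a higher number here means a weaker inhibitor, a lower number a stronger inhibitor
compound 2, `Cc1ccccc1Oc1ccc(C#N)cc1S(=O)(=O)NC(=O)NC(C)(C)C`, with 1470 nM in this assay

Compound 1 has the highest of the two numbers, so of the two it is the weaker inhibitor; its nearest neighbour is compound 2, and the step of a 4.2-fold lower number from compound 1 to compound 2 (0.62 log units; beyond the scatter) lies beyond the scatter. That one step is the only one measured, and it concerns a methyl in place of hydrogen on a saturated chain carbon bound to an amide-type nitrogen and two saturated chain carbons.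

Compound 3, `CC(C)NC(=O)NS(=O)(=O)c1cc(C#N)ccc1Oc1ccc(F)cc1`, is not yet measured. It differs from compound 1 at the other end of the molecule: 4-fluorophenyl in place of 2-methylphenyl on an oxygen on an aromatic ring. Among the measured compounds shown here, no measured step touches this part of the structure, so nothing here tells in which direction this exchange moves the number, or whether it moves it beyond the scatter at all. The expectation therefore starts from compound 1 itself, with a wide range on either side.

Compound 3 is estimated at 6000 nM in this assay, between 1500 nM and 25000 nM, which as a step means an expected 1.0-fold lower number from compound 1 to compound 3 (0.01 log units; within the scatter).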

Compound 3, half-maximal inhibitory concentration: 9300 nM
Compound 3: the middle estimate sits 1.6-fold (0.19 log units) below what was measured, within the range that was stated.
By their numbers in this assay, from the lowest: compound 2; then compounds 1 and 3 (each within the scatter of the next).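

The exchange of 2-methylphenyl for 4-fluorophenyl on an oxygen on an aromatic ring gives a 1.5-fold higher number from compound 1 to compound 3 (0.18 log units; within the scatter) in this assay, so this first reading at that end of the molecule shows no change that can be told apart from the ordinary spread of repeat measurements. The only earlier step, a 4.2-fold lower number from compound 1 to compound 2 (0.62 log units; beyond the scatter), concerned the saturated chain on the amide-type nitrogen and lies beyond the scatter, so among the compounds shown, only that change at the chain has moved the number measurably. No measurement on hand offers an explanation for either result.

This single exchange removes a methyl and adds a fluorine at once, so it leaves open whether each change alone would also leave the number within the scatter, or whether their separate effects offset each other. Also open, on these data alone, is whether 4-fluorophenyl would behave the same way alongside the chain of compound 2, and whether a larger change on this ring, such as a methoxy group, a chlorine or a carboxylic acid, would move the number beyond the scatter.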